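Swapping Acetyl for 1-(Ethoxycarbonyl)ethyl on the Shared Core

This account rests on a few compounds, and the source may have more. Where it says the series, first, only, none or still open, it means among the compounds named here.

In a functional assay on HL-60 cells (Homo sapiens) for cytotoxicity, read by MTT assay, with a stated time of 24 h (a lower number here means a stronger inhibitor, a higher number a weaker inhibitor), compound 1 (`BrCCCCOc1c(Br)cc(Br)cc1Oc1ccc(Br)cc1Br`) gives 25.9 ug/mL and compound 2 (`CC(=O)Oc1c(Br)cc(Br)cc1Oc1ccc(Br)cc1Br`) gives 29.9 ug/mL, two numbers within the scatter of each other. Compound 3 (`CCOC(=O)C(C)Oc1c(Br)cc(Br)cc1Oc1ccc(Br)cc1Br`) carries 1-(ethoxycarbonyl)ethyl in place of acetyl on an oxygen on an aromatic ring. Among the compounds with values here, the only measured step that bears on this, a 1.2-fold higher number from compound 1 to compound 2 (0.06 log units; within the scatter), exchanged groups on that same oxygen and stayed within the scatter. No step beyond the scatter is therefore expected in this assay, in either direction. For compound 3 the estimated value is 27 ug/mL, with an expected range of 13 ug/mL to 55 ug/mL.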

Compound 3, half-maximal inhibitory concentration: 35.7 ug/mL
Beside the measured number, compound 3's estimate is 1.3-fold (0.12 log units) below it, within the range that was stated.
By their numbers in this assay, from the lowest: compounds 1, 2 and 3 (each within the scatter of the next).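

In this assay, a third group on this oxygen again produces no step beyond the scatter (a 1.2-fold higher number from compound 2 to compound 3 (0.08 log units; within the scatter); a 1.4-fold higher number from compound 1 to compound 3 (0.14 log units; within the scatter)). Compound 3 thus extends the earlier result to 1-(ethoxycarbonyl)ethyl, so that this group, acetyl and 4-bromobutyl cannot be told apart at this position, although the entering group is larger than acetyl and has one more hydrogen-bond acceptor. No measured evidence bears on this result. The compounds shown leave open whether a carboxylic acid or an amine on this oxygen would also stay within the scatter.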